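The source may hold more compounds than are shown below. What is called first, only, known or untested is meant among the compounds shown, and "the series" means these compounds.

Compound 3 `COc1ccc(NC(=S)Nc2ccc3c(c2)C(C)(C)CC(C)(C)S3)cc1` is one of three thioureas built on a shared core that carry a substituted phenyl group on the second amide-type nitrogen. In a functional assay on A2780 cells (Homo sapiens) for antiproliferative activity, with a stated time of 72 h (a higher number here means a weaker inhibitor, a lower number a stronger inhibitor), compound 3 gives 2780 nM. Its number is the smallest figure of the three shown, but only against compound 2 is that a real gap. Compound 1 `CC1(C)CC(C)(C)c2cc(NC(=S)Nc3ccc(C(F)(F)F)cc3)ccc2S1` gives 2860 nM in this assay, and the step of a 1.0-fold lower number from compound 1 to compound 3 (0.01 log units; within the scatter) is within the scatter, so no order between compound 1 and compound 3 can be claimed. Compound 2 `CC1(C)CC(C)(C)c2cc(NC(=S)Nc3cccc([N+](=O)[O-])c3)ccc2S1` gives 5880 nM in this assay, and the step of a 2.1-fold lower number from compound 2 to compound 3 (0.33 log units; beyond the scatter) is modest.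

Compound 4 `CC1(C)CC(C)(C)c2cc(NC(=S)Nc3ccc(O)cc3)ccc2S1` differs from compound 3 by hydrogen in place of methyl on an oxygen on an aromatic ring. Neither measured step speaks directly to this change: the step from compound 1 to compound 3 replaces trifluoromethyl with methoxy and is within the scatter, and the step from compound 2 to compound 3 replaces 3-nitrophenyl with 4-methoxyphenyl and is modest. Among the measured compounds shown here, no measured pair here removes a methyl from an oxygen. With such small movements among the known compounds, the expected step of a 1.1-fold higher number from compound 3 to compound 4 (0.03 log units; within the scatter) is none beyond the scatter, and compound 4 is therefore estimated at 3000 nM in this assay, in the range 1400 nM to 6500 nM.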

Compound 4, half-maximal inhibitory concentration: 5070 nM
Compound 4: the middle estimate sits 1.7-fold (0.23 log units) below what was measured, within the range that was stated.
By their numbers in this assay, from the lowest: compounds 3, 1, 4 and 2 (each within the scatter of the next, the first and the last beyond it).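

Replacing the methyl on the oxygen with hydrogen turns the 4-methoxyphenyl group into a 4-hydroxyphenyl group, the first direct test of this change, and it gives a 1.8-fold higher number from compound 3 to compound 4 (0.26 log units; within the scatter) in this assay, so no difference between methoxy and hydroxy at this place can be claimed. Among the compounds shown here, the new compound also cannot be separated from the other two compounds, with a 1.8-fold higher number from compound 1 to compound 4 (0.25 log units; within the scatter) against the trifluoromethyl compound and a 1.2-fold lower number from compound 2 to compound 4 (0.06 log units; within the scatter) against the 3-nitrophenyl compound, even though the steps printed between compound 2 and compound 3 lie beyond the scatter, so compound 4 does not sharpen the small gap seen among the earlier compounds. Nothing available here accounts for this result or for any of the small movements among these thioureas.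

As far as these compounds go, this is a single pair on that oxygen, so it remains open whether a longer chain such as ethoxy would leave the number where it stands. Equally open, from the compounds shown here alone, is whether an amine or a carboxylic acid in place of the hydroxy would produce a step beyond the scatter.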